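Replacing a 4-Fluorobenzyl Ether With an Allyl Ether

The source may hold more compounds than are shown below. What is called first, only, known or untested is meant among the compounds shown, and "the series" means these compounds.

Measured so far:
Compound 1, `CN(C)CCNc1ccnc2cc(OCc3ccc(F)cc3)ccc12`: 810 nM
Compound 2, `CN(C)CCCNc1ccnc2cc(OCc3ccc(F)cc3)ccc12`: 2540 nM

Both compounds were tested in a functional assay on DLD-1 cells (Homo sapiens) for cytotoxicity, read by MTT assay, with a stated time of 48 h; on this read-out lower numbers stand for stronger inhibition and higher numbers for weaker inhibition. Among the measured compounds shown here, compound 2 holds the higher of the two numbers; its only neighbour is compound 1, and the step between them, a 3.1-fold higher number from compound 1 to compound 2 (0.50 log units; beyond the scatter), lies in the chain joining the two nitrogens, not in the ether part of the molecule.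

Compound 3, `C=CCOc1ccc2c(NCCCN(C)C)ccnc2c1`, has not yet been measured. It keeps the longer chain of compound 2 and differs from it at the ether side only: vinyl in place of 4-fluorophenyl on a saturated chain carbon bound to an oxygen on an aromatic ring. For the measured compounds named here, no measured step touches this part of the structure, so the single step known gives no guide to the size or direction of the change here. What can be leaned on is the value of compound 2 alone.

On that basis compound 3 is expected to give a modestly weaker result, a step of a 2.0-fold higher number from compound 2 to compound 3 (0.29 log units; within the scatter), held with wide uncertainty. The estimate for compound 3 in this assay is 5000 nM, expected to fall between 1500 nM and 20000 nM.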

Compound 3, half-maximal inhibitory concentration: 5180 nM
Estimate against measurement, compound 3: 1.0-fold (0.02 log units) below, within the range that was stated.
By their numbers in this assay, from the lowest: compound 1; then compound 2; then compound 3.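

In this assay, among the compounds shown here, the ether side of the molecule changes for the first time, and the result is a 2.0-fold higher number from compound 2 to compound 3 (0.31 log units; beyond the scatter), so this part of the structure does influence the read-out, as the chain step alone could not show. The change is large in structural terms, since the aromatic ring of 4-fluorophenyl is lost and vinyl, which has no ring, takes its place, yet the step is only modest: on this chain, compound 3 stays on the same read-out scale without that ring, though with a weaker result than compound 2. Nothing available here offers a measured explanation for this rise in the number.

These compounds leave open which part of the change matters, as the fluorine, the ring and the double bond all differ at once; an unsubstituted benzyl ether or a saturated propyl ether would help to separate them. On these data alone, it also remains open whether the allyl ether would give a step of similar size on the shorter chain of compound 1, since this change has been seen on the longer chain only.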